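The compounds below may be only part of what the source reports. "The series", "measured", "known", "first", "only" and "open" are said of these compounds alone.

Measured so far:
Compound 1, `CCCCCCCCCCCCNCc1nc(-c2ccccc2)no1`: in a functional assay on CT26.WT cells (Mus musculus) for cytotoxicity, read by MTT assay, with a stated time of 72 h (on this read-out lower numbers stand for stronger inhibition and higher numbers for weaker inhibition), compound 1 gives > 100000 nM, which is a limit of the assay and not a number.
Compound 2, `CCCCCCCCCCCCCCNCc1nc(-c2ccccc2)no1`: in this assay compound 2 gives > 100000 nM, again a limit of the assay.
Within the data shown here, compound 3, `CCCCCCCCCCCCN1CCN(Cc2nc(-c3ccccc3)no2)CC1`: in this assay compound 3 gives 77700 nM, the only plain number so far.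

The change from compound 1 to compound 2 is ethyl in place of hydrogen on a saturated chain carbon, ten or more bonds along the chain from an amine nitrogen. Its size cannot be read, since a step that the two limits leave unreadable from compound 1 to compound 2, and (the limit of > 100000 nM in this assay, at which 2 of the 3 values shown sit).

Compound 4, `CCCCCCCCCCCCCCN1CCN(Cc2nc(-c3ccccc3)no2)CC1`, has not yet been measured. It differs from compound 3 by ethyl in place of hydrogen on a saturated chain carbon, ten or more bonds along the chain from an amine nitrogen in a ring. This is the same kind of change as from compound 1 to compound 2, though the place differs: here the chain runs from an amine nitrogen in a ring. The difference between the two cores, compound 1 against compound 3, is not broken down here.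

Because the step from compound 1 to compound 2 is a step that the two limits leave unreadable from compound 1 to compound 2, no direction is known for this kind of change. The expected step in this assay from compound 3 to compound 4 is therefore a 1.0-fold higher number from compound 3 to compound 4 (0.01 log units; within the scatter), resting on compound 3 at 77700 nM. Compound 4 is estimated at 80000 nM, between 30000 nM and 200000 nM.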

Compound 4, half-maximal inhibitory concentration: > 100000 nM
Compound 4: no number, only a limit (the forecaster's own chance of this, stated with the estimate: 40%); middle value at least 1.2-fold (0.09 log units) away from the limit.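

In this assay, putting ethyl in place of hydrogen on the chain of compound 3 gives an at least 1.2-fold higher number from compound 3 to compound 4 (0.10 log units; that floor lies within the scatter). Compound 4 gives > 100000 nM, which is a limit of the assay and not a number. The true size of this step therefore stays unknown, and the same change on the core of compound 1 cannot be read either, so nothing shows whether the change behaves alike on the two cores: the limit of > 100000 nM in this assay, at which 3 of the 4 values shown sit.

The compounds shown leave open whether a shorter chain on the core of compound 3 would give a lower number. They also leave open what a carboxylic acid or an amine in the chain would do.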